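The source may hold more compounds than are shown below. What is called first, only, known or untested is meant among the compounds shown, and "the series" means these compounds.

Compound 3 `O=c1cc(Cn2cc(CCCO)nn2)c2ccc(O)cc2o1` carries a 3-hydroxypropyl chain on the shared core, and in a functional assay on A549 cells (Homo sapiens) for inhibition, read by MTT assay, with a stated time of 72 h (a lower number here means a stronger inhibitor, a higher number a weaker inhibitor), compound 3 gives 96200 nM, the highest of the two numbers obtained. Its nearest neighbour is compound 1 `O=c1cc(Cn2cc(CCCCl)nn2)c2ccc(O)cc2o1`, which in this assay gives 30100 nM; the step of a 3.2-fold higher number from compound 1 to compound 3 (0.50 log units; beyond the scatter) is modest but beyond the scatter. Compound 2 `CC(O)c1cn(Cc2cc(=O)oc3cc(O)ccc23)nn1` reaches only a limit of this assay, > 100000 nM, so the step of an at least 3.3-fold higher number from compound 1 to compound 2 (0.52 log units; beyond the scatter) is at least modest, while the step of an at least 1.0-fold lower number from compound 2 to compound 3 (0.01 log units; that floor lies within the scatter) has a floor that lies within the scatter. Compound 4 `O=c1cc(Cn2cc(CCCCO)nn2)c2ccc(O)cc2o1` is not yet measured; it differs from compound 3 by hydroxymethyl in place of hydroxy on a saturated chain carbon, three bonds along the chain from an aromatic carbon. Among the measured compounds shown here, the steps that bear on it are the exchange of a hydroxyalkyl chain for another hydroxyalkyl chain, which showed no change beyond the scatter, and the introduction of the hydroxy group itself, which raised the number. Compound 4 is therefore expected to give about 100000 nM, between 40000 nM and 250000 nM. That estimate means a step of a 1.0-fold higher number from compound 3 to compound 4 (0.02 log units; within the scatter), expected to stay within the scatter, with a fair chance that only a limit is reported.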

Compound 4, half-maximal inhibitory concentration: > 100000 nM
Compound 4: no number, only a limit; the forecaster's own chance of this, stated with the estimate: 50%; the middle value lies on the limit itself.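

Compound 4 yields only a limit in this assay, > 100000 nM. Hydroxymethyl in place of hydroxy on a saturated chain carbon, three bonds along the chain from an aromatic carbon, gives an at least 1.0-fold higher number from compound 3 to compound 4 (0.01 log units; that floor lies within the scatter), so the added carbon brings no lower number, while hydroxymethyl in place of chloro at the same place gives an at least 3.3-fold higher number from compound 1 to compound 4 (0.52 log units; beyond the scatter), so the longer hydroxy chain keeps the separation from the chloro chain already seen with compound 3. The step between compound 2 and compound 4 cannot be read because both stand at one limit: the limit of > 100000 nM in this assay, at which 2 of the 4 values shown sit.

From the compounds shown here alone, how far compound 4 lies beyond compound 3 stays open. Also open, going by these compounds, is how an amine or a carboxylic acid at the chain end, or a 4-chlorobutyl chain, would read on the shared core.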